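Bromo for Fluoro on the Fused Ring of Compound 3

This account rests on a few compounds, and the source may have more. Where it says the series, first, only, none or still open, it means among the compounds named here.

Compound 1, `Cc1ccc(NC(=S)N/N=C2\C(=O)Nc3ccc(Br)cc32)cc1`: 9600 nM
Compound 2, `O=C1/C(=N\NC(=S)Nc2ccc(Cl)cc2)c2cc(F)ccc2N1Cc1ccc(F)cc1`: 154000 nM
Compound 3, `Cc1ccc(NC(=S)N/N=C2\C(=O)N(Cc3ccc(F)cc3)c3ccc(F)cc32)cc1`: 6200 nM

In a functional assay on L1210 cells (Mus musculus), with a stated time of 48 h (on this read-out lower numbers stand for stronger inhibition and higher numbers for weaker inhibition), compound 3 gives the lowest of the three numbers. Among the measured compounds shown here, its nearest neighbour is compound 1, whose number lies within the scatter of it; the furthest is compound 2, separated by a 25-fold lower number from compound 2 to compound 3 (1.40 log units; beyond the scatter), the only measured step between single-change neighbours.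

Compound 4 `Cc1ccc(NC(=S)N/N=C2\C(=O)N(Cc3ccc(F)cc3)c3ccc(Br)cc32)cc1` differs from compound 3 in one place: bromo in place of fluoro on an aromatic carbon. For the measured compounds named here, no measured step concerns this change. Compound 1 carries bromo at the same place but lacks the benzyl group, and its number and that of compound 3 sit within the scatter of each other. For compound 4 the expected step is therefore a 1.1-fold higher number from compound 3 to compound 4 (0.05 log units; within the scatter), not beyond the scatter. Compound 4 is estimated at 7000 nM, within 2500 nM to 20000 nM.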

Compound 4, half-maximal inhibitory concentration: 190000 nM
Beside the measured number, compound 4's estimate is 27-fold (1.43 log units) below it; the measured number lies above the stated range.
By their numbers in this assay, from the lowest: compounds 3 and 1 (each within the scatter of the next); then compounds 2 and 4 (each within the scatter of the next).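

In this assay, bromo in place of fluoro on this aromatic carbon is far from neutral when the 4-fluorobenzyl group is present, giving a 31-fold higher number from compound 3 to compound 4 (1.49 log units; beyond the scatter). Adding that group to the bromo compound gives a 20-fold higher number from compound 1 to compound 4 (1.30 log units; beyond the scatter), so bromo and 4-fluorobenzyl, which each appear in a low-number compound, do not combine well here.

No evidence shown explains this jump. Open, on these data alone, is how a methoxy group or a nitrile on this carbon would fare alongside the 4-fluorobenzyl group, and what fluoro does with the amide hydrogen in place.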